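The compounds below may be only part of what the source reports. "The series", "measured", "known", "first", "only" and "open" are said of these compounds alone.

Measured in an ADME assay on J774.A1 cells (Mus musculus) for cytotoxicity, read by MTT assay, with a stated time of 72 h; on this read-out lower numbers stand for higher toxicity in this test and higher numbers for lower toxicity in this test:
- Compound 1 `CC1(c2ccc(-c3cccc(/C(N)=N\O)c3)cc2)CC(S(=O)(=O)c2ccc(F)cc2)=C(c2ccc(/C(N)=N\O)cc2)O1`: 11000 nM
- Compound 2 `CC1(c2ccc(-c3ccncc3)cc2)CC(S(=O)(=O)c2ccc(F)cc2)=C(c2ccc(/C(N)=N\O)cc2)O1`: 6750 nM
- Compound 3 `COc1cc(-c2ccc(C3(C)CC(S(=O)(=O)c4ccc(F)cc4)=C(c4ccc(/C(N)=N\O)cc4)O3)cc2)cc(OC)c1OC`: 5220 nM

Compound 3 cannot be told apart from compound 2, with a 1.3-fold lower number from compound 2 to compound 3 (0.11 log units; within the scatter), and it sits modestly apart from compound 1, with a 2.1-fold lower number from compound 1 to compound 3 (0.32 log units; beyond the scatter). Compound 4 `CC1(c2ccc(Br)cc2)CC(S(=O)(=O)c2ccc(F)cc2)=C(c2ccc(/C(N)=N\O)cc2)O1` carries bromo in place of 3,4,5-trimethoxyphenyl on an aromatic carbon. The third measured step, a 1.6-fold lower number from compound 1 to compound 2 (0.21 log units; within the scatter), is also small. All three exchange one aromatic ring group for another, and none removes that ring, so they bear on this change only indirectly. From steps of this size, no shift beyond the scatter is expected in this assay, and the data favour no direction. The expected step is a 1.2-fold higher number from compound 3 to compound 4 (0.10 log units; within the scatter). Compound 4 is estimated at 6500 nM, with an expected range of 3000 nM to 14000 nM.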

Compound 4, half-maximal cytotoxic concentration: 10500 nM
Compound 4: middle estimate off by 1.6-fold (0.21 log units), on the low side, and the stated range covers the measured number.
By their numbers in this assay, from the lowest: compounds 3, 2, 4 and 1 (each within the scatter of the next, the first and the last beyond it).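

The earlier steps shown here only exchanged one aromatic ring group for another, whereas bromo leaves no ring at this place on the aromatic carbon. In this assay, all three new steps stay within the scatter (a 2.0-fold higher number from compound 3 to compound 4 (0.30 log units; within the scatter); a 1.6-fold higher number from compound 2 to compound 4 (0.19 log units; within the scatter); a 1.0-fold lower number from compound 1 to compound 4 (0.02 log units; within the scatter)). Among these compounds, then, the number does not depend on a ring group being present at this position, and nothing measured here offers a reason for this. Still open, going by these compounds, is whether an amine, a carboxylic acid or a longer chain at this position would leave the number equally unchanged.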